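Bromo on the Benzyl Ring, Tried on a Methoxy Core

The source may hold more compounds than are shown below. What is called first, only, known or untested is meant among the compounds shown, and "the series" means these compounds.

Of the compounds shown here, three have been measured in a functional assay on HepG2 cells (Homo sapiens) for inhibition, read by MTT assay, with a stated time of 48 h, tested at 10 uM; a higher number here means more inhibition of growth at the concentration tested, a lower number less inhibition of growth: compound 1 `O=C(/C=C/c1ccc(OCc2cn(Cc3ccccc3)nn2)cc1)c1ccc(Br)cc1` gives 22%, compound 2 `O=C(/C=C/c1ccc(OCc2cn(Cc3cccc(Br)c3)nn2)cc1)c1ccc(Br)cc1` gives 25%, and compound 3 `COc1ccc(C(=O)/C=C/c2ccc(OCc3cn(Cc4ccccc4)nn3)cc2)cc1` gives 51%.

Compound 1 and compound 2 share one core and differ by bromo in place of hydrogen on an aromatic carbon. That change made a step of a number 3 percentage points higher from compound 1 to compound 2 (within the scatter). Compound 3 has a different core; the difference between the cores is methoxy in place of bromo on an aromatic carbon, with a step of a number 29 percentage points higher from compound 1 to compound 3 (beyond the scatter). Compound 4 `COc1ccc(C(=O)/C=C/c2ccc(OCc3cn(Cc4ccccc4Br)nn3)cc2)cc1` is not yet measured and differs from compound 3 by bromo in place of hydrogen on an aromatic carbon. The place is not the same word for word: in compound 2 the bromo stands meta to a large group, in compound 4 ortho to a large group, so this is the same kind of change, not the same one. The step is expected to be small, a number 1 percentage points higher from compound 3 to compound 4 (within the scatter), because a number 3 percentage points higher from compound 1 to compound 2 (within the scatter) lay within the scatter. Compound 4 is therefore estimated at 52%, between 38% and 66%.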

Compound 4, percent growth inhibition at one concentration: 44%
Compound 4: middle estimate off by 8 percentage points, on the high side; low and high end bracket the measured number.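

Putting bromo in place of hydrogen on the core of compound 3 gave a step of a number 7 percentage points lower from compound 3 to compound 4 (within the scatter) in this assay. Set side by side, the two steps do not differ, so in these compounds the change carries from one core to the other as a step too small to read: the same change on two cores in this assay, a number 3 percentage points higher (within the scatter) from compound 1 to compound 2 and a number 7 percentage points lower (within the scatter) from compound 3 to compound 4, 10 percentage points apart, within the scatter of two such steps

This does not show that bromo makes no difference anywhere on the benzyl ring: it stands in a different place in each pair, so the comparison cannot separate the effect of the core from that of the place.

Still open, on these data alone, is what an amine or a carboxylic acid would do on this ring. As far as these compounds go, it is also open whether a longer chain in place of benzyl would move the number beyond the scatter.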